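Methoxy in Place of Methyl on an Aromatic Ring

The source may report more compounds than this note shows. Statements on the series, on what has been measured and on what is new or still open speak of the compounds shown alone.

Of the compounds shown here, two have so far been measured in a functional assay on A2780 cells (Homo sapiens) for inhibition; on this read-out lower numbers stand for stronger inhibition and higher numbers for weaker inhibition. Compound 1 `Cc1ccc(-c2cc(C)oc(=O)c2)cc1` carries a methyl group on its aromatic ring. In this assay compound 1 gives > 50000 nM, which is a limit of the assay rather than a number. Compound 2 `CCCC#Cc1cc(C)oc(=O)c1` gives 4800 nM in this assay. On the numbers shown, compound 1 stands at the limit of > 50000 nM in this assay, at which 1 of the 2 values shown sits, so only a lower bound on its half-maximal inhibitory concentration is known, and no step between two measured compounds has been worked out.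

Compound 3 `COc1ccc(-c2cc(C)oc(=O)c2)cc1` is the one yet to be measured. It differs from compound 1 by methoxy in place of methyl on an aromatic carbon. Because compound 1 sits at > 50000 nM, a change of this small size is expected to leave compound 3 close to that limit, and the step that the limit leaves unreadable from compound 1 to compound 3 is expected to be none beyond the scatter. For compound 3 the half-maximal inhibitory concentration in this assay is estimated at 60000 nM, most likely between 15000 nM and 200000 nM, with a good chance that only a limit is reported.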

Compound 3, half-maximal inhibitory concentration: > 50000 nM
Compound 3: a limit, no number; the forecaster's own chance of this, stated with the estimate: 65%; the middle value lies beyond the limit too.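

No step can be read between compound 1 and compound 3 in this assay, because each stands at a limit rather than a number: the limit of > 50000 nM in this assay, at which 2 of the 3 values shown sit.

Left open is what number either compound would give, and so whether methoxy in place of methyl on an aromatic carbon changes the inhibition at all.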